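The source may report more compounds than this note shows. Statements on the series, on what has been measured and on what is new or still open speak of the compounds shown alone.

Working notes on a series built on the core of compound 1 `CC(C)N1C(=O)C=C(Cl)C1(O)c1ccccc1`, varied only at the amide-type nitrogen in the ring. In an assay on cell membranes for displacement of a labelled ligand from Cholecystokinin receptor type A (Rattus norvegicus), read by CCK-8 assay, with a stated time of 2 h (on this read-out lower numbers stand for stronger inhibition and higher numbers for weaker inhibition), compound 1 gives 200 nM. Compound 2 `O=C1C=C(Cl)C(O)(c2ccccc2)N1C1CCCC1` gives 360 nM in this assay, and the step of a 1.8-fold higher number from compound 1 to compound 2 (0.26 log units; within the scatter) stays within the scatter. Compound 3 `CC(C)CN1C(=O)C=C(Cl)C1(O)c1ccccc1` gives 20 nM in this assay, the lowest of the three numbers: a 10-fold lower number from compound 1 to compound 3 (1.00 log units; beyond the scatter) and an 18-fold lower number from compound 2 to compound 3 (1.26 log units; beyond the scatter).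

Compound 4 `CCCCCCN1C(=O)C=C(Cl)C1(O)c1ccccc1` has not yet been measured in this assay. The change from compound 3 is pentyl in place of isopropyl on a saturated chain carbon bound to an amide-type nitrogen in a ring. Going by the values given here, two measured steps bear on this position, and both replaced a branched or cyclic group with isobutyl and lowered the number, one modestly and one by a large amount. Among the compounds with values here, neither shows what a long unbranched chain does at this place; no measured pair tests pentyl or hexyl here. The expectation rests only on the observation that the isobutyl compound 3 gave the lowest number, so a move away from it in either direction is open. For compound 4 in this assay the estimate is 40 nM, with a range from 8 nM to 250 nM. The expected step is a 2.0-fold higher number from compound 3 to compound 4 (0.30 log units; within the scatter), wide enough to include no change beyond the scatter.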

Compound 4, half-maximal inhibitory concentration: 4500 nM
Compound 4: the middle estimate sits 110-fold (2.05 log units) below what was measured; the measured number lies above the stated range.
By their numbers in this assay, from the lowest: compound 3; then compounds 1 and 2 (each within the scatter of the next); then compound 4.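

In this assay, going by these compounds alone, the position proves far less permissive than the earlier compounds suggested: hexyl gives the highest number of the series, with (a 230-fold higher number from compound 3 to compound 4 (2.35 log units; beyond the scatter)) against isobutyl, (a 23-fold higher number from compound 1 to compound 4 (1.35 log units; beyond the scatter)) against isopropyl and (a 13-fold higher number from compound 2 to compound 4 (1.10 log units; beyond the scatter)) against cyclopentyl, so the unbranched chain ranks behind the branched and cyclic groups alike. Isobutyl and hexyl share the saturated chain carbon bound to the amide-type nitrogen in the ring, so a change further out on the chain is enough to produce the largest step seen at this position. Nothing at hand gives a reason for this loss.

The compounds shown leave open whether the number climbs steadily or abruptly between isobutyl and hexyl, which a butyl or pentyl chain on the same nitrogen would test. They also leave open whether the loss follows chain length alone or would change with a hexyl-length chain ending in an amine or a carboxylic acid, or with a branched chain such as isopentyl.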